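The source may hold more compounds than are shown below. What is called first, only, known or untested is meant among the compounds shown, and "the series" means these compounds.

Working notes on the series. Compound 1 `CN1CCN(c2ccc(Nc3ncc(/N=C/c4ccc(C(F)(F)F)cc4)c(NC4CCCC4)n3)cc2)CC1` in a functional assay on HeLa cells (Homo sapiens) for antiproliferative activity, read by MTT assay (a lower number here means a stronger inhibitor, a higher number a weaker inhibitor), returns only a limit, > 100000 nM. Compound 2 `NS(=O)(=O)c1ccc(Nc2ncc(/N=C/c3ccc(C(F)(F)F)cc3)c(NC3CCCC3)n2)cc1` gives 21900 nM in this assay. For the measured compounds named here, the one change between them is sulfamoyl in place of 4-methylpiperazin-1-yl on an aromatic carbon, and the step of an at least 4.5-fold lower number from compound 1 to compound 2 (0.65 log units; beyond the scatter) is reported as a lower bound because compound 1 sits at the limit of > 100000 nM in this assay, at which 1 of the 3 values shown sits.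

Compound 3 `CCOC(=O)/C=N/c1cnc(Nc2ccc(N3CCN(C)CC3)cc2)nc1NC(C)C` carries a different core; in this assay compound 3 gives 11500 nM, which lies within the scatter of compound 2. The difference between the core of compound 3 and the core of compound 1 is not broken down here.

Compound 4 `CCOC(=O)/C=N/c1cnc(Nc2ccc(S(N)(=O)=O)cc2)nc1NC(C)C` is not yet measured. It relates to compound 3 by sulfamoyl in place of 4-methylpiperazin-1-yl on an aromatic carbon, the same change, at the same place, as that between compound 1 and compound 2. Set beside an at least 4.5-fold lower number from compound 1 to compound 2 (0.65 log units; beyond the scatter), the expected step is a 3.8-fold lower number from compound 3 to compound 4 (0.58 log units; beyond the scatter); this rests on the single measured pair, and on a bound rather than a number, so it is held loosely. Compound 4 is therefore estimated at 3000 nM in this assay, from 800 nM to 12000 nM.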

Compound 4, half-maximal inhibitory concentration: 83300 nM
Compound 4: middle estimate off by 28-fold (1.44 log units), on the low side; the whole stated range lies below it.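

In this assay, sulfamoyl in place of 4-methylpiperazin-1-yl gives a 7.2-fold higher number from compound 3 to compound 4 (0.86 log units; beyond the scatter), the opposite direction to the step on the core of compound 1. The change therefore does not carry over from one core to the other among the compounds shown, and the two steps differ in direction and beyond what scatter allows: the same change on two cores in this assay, an at least 4.5-fold lower number (0.65 log units; beyond the scatter) from compound 1 to compound 2 and a 7.2-fold higher number (0.86 log units; beyond the scatter) from compound 3 to compound 4, at least 33-fold (1.51 log units) apart, beyond the scatter of two such steps It does not show which of the differences between the two cores lies behind the reversal, and the step on the core of compound 1 rests on a limit for compound 1, not on a number: the limit of > 100000 nM in this assay, at which 1 of the 4 values shown sits.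

Open, from the compounds shown here alone, is whether a core carrying only one of the differences between the core of compound 1 and the core of compound 3 would behave like the first pair or the second. Also open, going by these compounds, is how a carboxylic acid or a primary amine would behave at the same place on each core.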